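This account rests on a few compounds, and the source may have more. Where it says the series, first, only, none or still open, it means among the compounds named here.

Compound 1, `O=C(O)c1ccc(CN2C(=O)S/C(=C\c3ccc(F)cc3)C2=O)cc1`, gives 32000 nM in a functional assay on HT-29 cells (Homo sapiens) for cytotoxicity, read by MTT assay, with a stated time of 24 h; on this read-out lower numbers stand for stronger inhibition and higher numbers for weaker inhibition.
Compound 2, `COc1cccc(/C=C2\SC(=O)N(Cc3ccc(C(=O)O)cc3)C2=O)c1`, gives 48000 nM in this assay.
Compound 3, `O=C(O)c1ccc(CN2C(=O)S/C(=C\c3ccco3)C2=O)cc1`, gives 94000 nM in this assay.

Among these three, compound 1 has the lowest number. Its nearest neighbour is compound 2, reached by a step of a 1.5-fold higher number from compound 1 to compound 2 (0.18 log units; within the scatter), and its furthest is compound 3, reached by a step of a 2.9-fold higher number from compound 1 to compound 3 (0.47 log units; beyond the scatter); between those two stands the step of a 2.0-fold higher number from compound 2 to compound 3 (0.29 log units; within the scatter). For the measured compounds named here, only the step to compound 3 is large enough to count as a real difference.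

The unmeasured compound 4, `COc1ccc(/C=C2\SC(=O)N(Cc3ccc(C(=O)O)cc3)C2=O)cc1`, shares the core of compound 1 and differs from it in one place: methoxy in place of fluoro on an aromatic carbon. The step from compound 1 to compound 2 is the one that speaks to this change, since it also replaces the 4-fluorophenyl group with a phenyl ring carrying a methoxy group, and that step was small, a 1.5-fold higher number from compound 1 to compound 2 (0.18 log units; within the scatter). The steps toward compound 3 concern a furan-2-yl ring and bear less on a methoxy at this place. Compound 4 is therefore expected to land close to compound 1, with at most a small rise in number, an estimated step of a 1.3-fold higher number from compound 1 to compound 4 (0.10 log units; within the scatter). The estimate for compound 4 in this assay is 40000 nM, between 20000 nM and 80000 nM.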

Compound 4, half-maximal inhibitory concentration: 44000 nM
Compound 4: the middle estimate sits 1.1-fold (0.04 log units) below what was measured, within the range that was stated.
By their numbers in this assay, from the lowest: compounds 1, 4, 2 and 3 (each within the scatter of the next, the first and the last beyond it).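

For the compounds shown here, the single change of fluoro to methoxy, on an aromatic carbon para to a large group, can now be read on its own: in this assay it gives a 1.4-fold higher number from compound 1 to compound 4 (0.14 log units; within the scatter) and so cannot be told apart from repeat measurement, whereas the earlier step from compound 1 to compound 2 also shifted the group's place on the ring. Comparing the two methoxy compounds isolates that shift, 3-methoxyphenyl against 4-methoxyphenyl, and a 1.1-fold lower number from compound 2 to compound 4 (0.04 log units; within the scatter) shows that this read-out does not separate them either. The furan-2-yl compound now stands apart from a second phenyl compound, with a 2.1-fold lower number from compound 3 to compound 4 (0.33 log units; beyond the scatter) beyond the scatter, although the pattern is not clean: compound 2 goes against it, since a 2.0-fold higher number from compound 2 to compound 3 (0.29 log units; within the scatter) stays within the scatter.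

Nothing available gives a reason for the size of any of these steps. Going by these compounds alone, it also remains open whether this place tolerates every group in the same way, for example an amine, a nitrile or a longer chain such as butoxy on the phenyl ring, since fluoro and methoxy are the only two groups compared there.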